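Methoxy for methyl on compound 3

The source may report more compounds than this note shows. Statements on the series, on what has been measured and on what is new or still open speak of the compounds shown alone.

In an ADME assay on MDCK cells (Canis lupus familiaris) for cytotoxicity (on this read-out lower numbers stand for higher toxicity in this test and higher numbers for lower toxicity in this test), compound 1 (`O=C1NC(=O)C(N2N=C(c3ccc4ccccc4c3)CC2c2ccc(Cl)cc2)S1`) gives 3080 nM. Compound 3 (`Cc1ccc(NC(=O)CN2C(=O)SC(N3N=C(c4ccc5ccccc5c4)CC3c3ccc(Cl)cc3)C2=O)cc1`) has only a limit, > 13300 nM, so its true value is not known. Compound 2 (`COc1ccc(C2CC(c3ccc4ccccc4c3)=NN2C2SC(=O)N(CC(=O)Nc3ccc(C)cc3)C2=O)cc1`) also has only a limit, > 74300 nM.

Compound 4 (`COc1ccc(NC(=O)CN2C(=O)SC(N3N=C(c4ccc5ccccc5c4)CC3c3ccc(Cl)cc3)C2=O)cc1`) differs from compound 3 by methoxy in place of methyl on an aromatic carbon, para to a large group: methoxy in place of methyl on an aromatic carbon.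

Within the data shown here, two measured steps bear on this change, though neither makes it. Adding the ((4-methylphenyl)carbamoyl)methyl group produced an at least 4.3-fold higher number from compound 1 to compound 3 (0.63 log units; beyond the scatter), which is beyond the scatter but lies at another place in the molecule. The other step, a step that the two limits leave unreadable from compound 2 to compound 3, involves methoxy but gives no size.

Among the measured compounds shown here, with no measured step for this swap, no change beyond the scatter is expected in this assay. The expected step is a step that the limit leaves unreadable from compound 3 to compound 4, and the assay may again report only a limit. Compound 4 is estimated at 20000 nM, within an expected range of 7000 nM to 80000 nM.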

Compound 4, half-maximal cytotoxic concentration: > 25600 nM
Compound 4: a limit, no number; the forecaster's own chance of this, stated with the estimate: 70%; middle value at least 1.2-fold (0.10 log units) from the limit.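

Like the methyl compound, compound 4 reads only as a limit in this assay, > 25600 nM. With the ((4-methoxyphenyl)carbamoyl)methyl group in place of hydrogen on the amide-type nitrogen in a ring, the result is an at least 8.3-fold higher number from compound 1 to compound 4 (0.91 log units; beyond the scatter), so the rise seen with the methyl-bearing group, an at least 4.3-fold higher number from compound 1 to compound 3 (0.63 log units; beyond the scatter), also appears with methoxy on this aromatic carbon. The steps among compound 2, compound 3 and compound 4 cannot be read, as each of these compounds has only a limit.

From the compounds shown here alone, whether methoxy and methyl differ at all at this position therefore stays open. The compounds shown also do not tell how an amine or a carboxylic acid on this aromatic carbon, para to a large group, would read in this assay.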